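Allyl addition on a coumarin ether series

The source may hold more compounds than are shown below. What is called first, only, known or untested is meant among the compounds shown, and "the series" means these compounds.

Compound 1 `C=CC(C)(C)Oc1ccc2ccc(=O)oc2c1` gives 0.3 ug/mL in an assay on LNCaP cells for inhibition of 3-oxo-5-alpha-steroid 4-dehydrogenase 1 (Homo sapiens); a lower number here means a stronger inhibitor, a higher number a weaker inhibitor.
Compound 2 `C=CCc1c(OC(C)=O)ccc2ccc(=O)oc12` gives 0.2 ug/mL in this assay.
Compound 3 `C=CCc1c(OCCO)ccc2ccc(=O)oc12` gives > 20 ug/mL in this assay; this is a limit of the assay and not a number (the limit of > 20 ug/mL in this assay, at which 1 of the 3 values shown sits).

Of the two numbers shown, compound 1 stands at the higher, with compound 2 nearest and within the scatter. Compound 4 `C=CCc1c(OC(C)(C)C=C)ccc2ccc(=O)oc12` differs from compound 1 by allyl in place of hydrogen on an aromatic carbon. Among the measured compounds shown here, the only measured step, an at least 100-fold higher number from compound 2 to compound 3 (2.00 log units; beyond the scatter), concerns the group on the oxygen and not the allyl, so no measured step bears directly on adding the allyl. Compound 2 carries the allyl and sits close to compound 1, which carries none. Compound 4 is therefore expected to show no step beyond the scatter in this assay, no change at the digits printed from compound 1 to compound 4 (within the scatter). The estimate for compound 4 is 0.3 ug/mL, expected between 0.1 ug/mL and 1 ug/mL.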

Compound 4, half-maximal inhibitory concentration: 13.6 ug/mL
Beside the measured number, compound 4's estimate is 45-fold (1.66 log units) below it, outside the stated range (above it).
By their numbers in this assay, from the lowest: compounds 2 and 1 (each within the scatter of the next); then compound 4. At a limit, above all of these: compound 3.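

In this assay, allyl in place of hydrogen on the aromatic carbon ortho to the (1,1-dimethylprop-2-en-1-yl)oxy group gives a 45-fold higher number from compound 1 to compound 4 (1.66 log units; beyond the scatter). With allyl held, the group on the oxygen still decides the number, as 1,1-dimethylprop-2-en-1-yl in place of acetyl gives a 68-fold higher number from compound 2 to compound 4 (1.83 log units; beyond the scatter), so allyl alone does not set it. Compound 3 stands at a limit of the assay and not at a number: the limit of > 20 ug/mL in this assay, at which 1 of the 4 values shown sits. With allyl held, 1,1-dimethylprop-2-en-1-yl in place of 2-hydroxyethyl on the oxygen gives an at least 1.4-fold lower number from compound 3 to compound 4 (0.16 log units; that floor lies within the scatter), and this step is only a floor.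

Open, from the compounds shown here alone, is whether a propyl group at this carbon behaves as allyl does. Also open, going by these compounds, is whether a methyl ether on the oxygen would keep the number low with allyl present.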